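This account rests on a few compounds, and the source may have more. Where it says the series, first, only, none or still open, it means among the compounds named here.

Compound 1, `Cc1cn2c(-c3cn[nH]c3)cnc2c(Nc2cc(Cn3cccc3)ns2)n1`: "not determined" (no result reported) in an ADME assay on the whole organism for pharmacokinetics, with Rattus norvegicus as the target, with a stated time of 6 h, at a dose of 10 mg/kg by the oral route; a higher number here means more compound in the circulation at the dose given, a lower number less compound in the circulation.
Compound 2, `Cc1cn2c(-c3cn[nH]c3)cnc2c(Nc2cc(Cc3cnccn3)ns2)n1`: 58.4 ng.h/mL.
Compound 3, `Cc1cn2c(-c3cn[nH]c3)cnc2c(Nc2cc(Cc3ncccc3C)ns2)n1`: 644 ng.h/mL.

All three compounds share one core and differ only in the ring held on a saturated chain carbon bound to an aromatic carbon. Going by the values given here, for compound 1 no number exists in this assay, so it cannot be placed between compounds 2 and 3; what is known is only that compound 2 gives 58.4 ng.h/mL and compound 3 gives 644 ng.h/mL.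

Compound 4, `Cc1ccnc(Cc2cc(Nc3nc(C)cn4c(-c5cn[nH]c5)cnc34)sn2)c1`, is the one still to be measured. Its difference from compound 1 is 4-methylpyridin-2-yl in place of 1H-pyrrol-1-yl on a saturated chain carbon bound to an aromatic carbon. Among the compounds with values here, the single measured step that comes close to this change is an 11-fold higher number from compound 2 to compound 3 (1.04 log units; beyond the scatter), a large step in which the methylpyridinyl partner gave the higher number. Compound 4 carries a 4-methylpyridin-2-yl, a close relative of the 3-methylpyridin-2-yl in compound 3, so its value is expected to sit near that of compound 3 because compound 3 gives 644 ng.h/mL. With no number for compound 1, no direction or size of step from compound 1 to compound 4 can be stated; only a stand-alone estimate is possible. Compound 4 is therefore expected to give about 450 ng.h/mL, with a likely range from 120 ng.h/mL to 1600 ng.h/mL.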

Compound 4, area under the concentration-time curve: 1850 ng.h/mL
Compound 4: the middle estimate sits 4.1-fold (0.61 log units) below what was measured, outside the stated range (above it).
By their numbers in this assay, from the lowest: compound 2; then compound 3; then compound 4.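

At this place, on a saturated chain carbon bound to an aromatic carbon, the two methylpyridinyl groups do not behave alike in this assay: 4-methylpyridin-2-yl in place of 3-methylpyridin-2-yl gives a 2.9-fold higher number from compound 3 to compound 4 (0.46 log units; beyond the scatter), so where the methyl sits on the pyridine ring changes the result, something compound 2 and compound 3 alone could not show. The comparison with the pyrazin-2-yl group is now a 32-fold higher number from compound 2 to compound 4 (1.50 log units; beyond the scatter), which widens the span seen for this single ring swap and leaves compound 4 with the highest number of the measured compounds. No measurement given here bears on why these rings give such different numbers.

From the compounds shown here alone, compound 1 has no number, so its step to compound 4 and every other step involving it cannot be read, and the place of the 1H-pyrrol-1-yl group stays unknown. Also open, going by these compounds, is how a plain pyridin-2-yl ring without a methyl, or a 4-methoxypyridin-2-yl or 4-chloropyridin-2-yl ring, would compare with the 4-methylpyridin-2-yl group of compound 4.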